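Vinyl for chloro on the exocyclic chain of the core

A few compounds are considered here, and "the series" means these few. Any claim that something is new, unique, unknown or untested is made for them only; others in the source may bear on it.

Compound 3 `CC1=C/C(=C\Cl)C(=O)C(C)(O)C12CC2` gives 300 nM in a functional assay on MDA-MB-231 cells (Homo sapiens) for antiproliferative activity; a lower number here means a stronger inhibitor, a higher number a weaker inhibitor. This is level with compound 1 `CC1=C/C(=C\C(C)C)C(=O)C(C)(O)C12CC2`, which gives 300 nM in this assay; no change at the digits printed from compound 1 to compound 3 (within the scatter). Together these two are the lowest of the three numbers in hand. Compound 2 `CC1=C/C(=C\c2ccccc2)C(=O)C(C)(O)C12CC2` stands furthest off with 4000 nM in this assay, and a 13-fold lower number from compound 2 to compound 3 (1.12 log units; beyond the scatter).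

Compound 4 `C=C/C=C1\C=C(C)C2(CC2)C(C)(O)C1=O` has not been measured in this assay. It differs from compound 3 in one place: vinyl in place of chloro on a double-bonded chain carbon bound to a double-bonded ring carbon.

Within the data shown here, two measured steps touch the same position. Exchanging isopropyl for chloro left the number unchanged: no change at the digits printed from compound 1 to compound 3 (within the scatter). Exchanging phenyl for chloro moved it substantially: a 13-fold lower number from compound 2 to compound 3 (1.12 log units; beyond the scatter). Among the measured compounds shown here, a vinyl group at this position has no measured precedent, so the direction rests on these two changes alone. One of them shows the position tolerant of an exchange, the other shows it sensitive to one, and the present exchange gives no measured reason to favour the larger outcome.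

The expectation for compound 4 is therefore a step of a 1.3-fold higher number from compound 3 to compound 4 (0.12 log units; within the scatter), within or near the scatter. Compound 4 is estimated at 400 nM in this assay, with a range from 150 nM to 1200 nM.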

Compound 4, half-maximal inhibitory concentration: 28 nM
The estimate for compound 4 lay 14-fold (1.15 log units) above the measured number, outside the stated range (below it).
By their numbers in this assay, from the lowest: compound 4; then compounds 1 and 3 (each within the scatter of the next); then compound 2.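

In this assay, the position on a double-bonded chain carbon bound to a double-bonded ring carbon proves able to give a gain beyond the level shared by compound 1 and compound 3, which had looked like a floor for the series: the change shows an 11-fold lower number from compound 3 to compound 4 (1.03 log units; beyond the scatter) and an 11-fold lower number from compound 1 to compound 4 (1.03 log units; beyond the scatter) as two steps of equal size. With a 140-fold lower number from compound 2 to compound 4 (2.15 log units; beyond the scatter) as the widest step in the set, the span at this one position is much larger than the phenyl, isopropyl and chloro compounds alone showed, and the identical numbers for isopropyl and chloro gave no sign of what vinyl would do. Nothing in hand bears on the cause of this gain.

The compounds shown leave open whether the gain depends on the double bond of the vinyl group, which an ethyl group at the same place would test directly. They also leave open whether a longer chain carrying a double bond, such as a butadienyl group, or a nitrile would keep, extend or lose the gain.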